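Butyl for methoxy on the four-membered ring

A few compounds are considered here, and "the series" means these few. Any claim that something is new, unique, unknown or untested is made for them only; others in the source may bear on it.

Measured compounds:
compound 1 `CO[C@@H]1C(=O)N(C(C)=O)[C@@H]1c1ccccc1`: 400 nM
compound 2 `CO[C@@H]1C(=O)N(C(C)=O)[C@@H]1C(C)=O`: 11000 nM

Among the measured compounds shown here, in an assay on isolated protein for inhibition of chymotrypsin-like elastase family member 2A (Rattus norvegicus) (a lower number here means a stronger inhibitor, a higher number a weaker inhibitor), compound 2 gives 11000 nM, the higher of the two numbers measured so far. Compound 1 gives 400 nM, and the gap between the two is beyond the usual scatter. Compound 3 `CCCC[C@@H]1C(=O)N(C(C)=O)[C@@H]1C(C)=O` differs from compound 2 by butyl in place of methoxy on a saturated ring carbon. No comparable change has been measured in this series, so direction and size rest on expectation alone; a moderate move toward a lower number is expected, a 2.8-fold lower number from compound 2 to compound 3 (0.44 log units; beyond the scatter). For compound 3 the estimated value is 4000 nM, with an expected range from 800 nM to 20000 nM.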

Compound 3, half-maximal inhibitory concentration: 37000 nM
Compound 3: the middle estimate sits 9.3-fold (0.97 log units) below what was measured, outside the stated range (above it).
By their numbers in this assay, from the lowest: compound 1; then compound 2; then compound 3.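

Butyl in place of methoxy on a saturated ring carbon gives a 3.4-fold higher number from compound 2 to compound 3 (0.53 log units; beyond the scatter) in this assay, so this position of the series responds to the substituent and the chain does not improve on methoxy. The exchange removes a hydrogen-bond acceptor and adds heavy atoms, and this single pair cannot separate the two differences. No measured evidence accounts for the step.

Open, as far as these compounds go, is how an ethoxy group, a shorter ethyl chain or an amine would read at this position. Also open, from the compounds shown here alone, is whether butyl would give a similar step on the core of compound 1.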